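The source may hold more compounds than are shown below. What is called first, only, known or untested is meant among the compounds shown, and "the series" means these compounds.

Measured compounds in a physicochemical assay for solubility, using the shake flask method, measured as kinetic solubility, with a stated time of 20 h, at pH 2; on this read-out lower numbers stand for lower solubility and higher numbers for higher solubility:

compound 1 `COc1ccc(Nc2cc3[nH]c(-c4cccc(C(F)(F)F)c4)nc3cn2)nc1` gives < 5000 nM
compound 2 `Fc1cnc(Nc2cc3[nH]c(-c4cccc(C(F)(F)F)c4)nc3cn2)c(F)c1` gives < 5000 nM
compound 3 `O=C(O)c1ccnc(Nc2cc3[nH]c(-c4cccc(C(F)(F)F)c4)nc3cn2)c1` gives < 5000 nM

Each of these three values is a limit of this assay, not a number. Compound 1 therefore stands at that limit, and so do compound 2 and compound 3; all three sit at the limit of < 5000 nM in this assay, at which 3 of the 3 values shown sit. The measured steps are a step that the two limits leave unreadable from compound 1 to compound 2, a step that the two limits leave unreadable from compound 1 to compound 3 and a step that the two limits leave unreadable from compound 2 to compound 3. For the measured compounds named here, no measured step in this set gives a readable size.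

Compound 4 `FC(F)(F)c1cccc(-c2nc3cnc(Nc4ccc(-c5nnn[nH]5)cn4)cc3[nH]2)c1` differs from compound 1 in one place: 1H-tetrazol-5-yl in place of methoxy on an aromatic carbon. The measured steps that bear on this change all start from compound 1 and all end at the same limit, so they give no direction and no size for what a new group at this position does. The only thing they show is that three different groups at the same nitrogen of the shared core of compound 1 leave the solubility at the limit.

Going by the values given here, compound 4 is therefore expected to show a step that the limit leaves unreadable from compound 1 to compound 4 in this assay, which is no step that can be read. The estimate for compound 4 in this assay is 3000 nM, with a range from 500 nM to 15000 nM, and it is expected that this assay again reports only the limit for compound 4 rather than a number.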

Compound 4, solubility: < 5000 nM
Compound 4: only a limit was reported; the forecaster's own chance of this, stated with the estimate: 70%; the middle value lies beyond the limit too.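

Compound 1 and compound 4 both stand at a limit of this assay, not at a number, so no step between them can be read: the limit of < 5000 nM in this assay, at which 4 of the 4 values shown sit.

The compounds shown leave open where any of the four actually lies relative to that limit, and whether exchanging groups on the shared core changes the read-out at all.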